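This account rests on a few compounds, and the source may have more. Where it says the series, first, only, none or still open, it means among the compounds named here.

Values in a functional assay on SF-268 cells (Homo sapiens) for cytotoxicity, read by MTT assay, with a stated time of 3 days; a higher number here means a weaker inhibitor, a lower number a stronger inhibitor:
compound 1 `CN1CCN(c2nc(SCc3nc4ccccc4[nH]3)nc(-c3ccccc3)c2C#N)CC1`: 6.9 nM
compound 2 `Cc1ccc(S(=O)(=O)N2CCN(c3nc(SCc4nc5ccccc5[nH]4)nc(-c4ccccc4)c3C#N)CC2)cc1`: 7.81 nM

Compound 2 stands within the scatter of compound 1, so this pair cannot be ordered on the numbers. Compound 3 `N#Cc1c(-c2ccccc2)nc(SCc2nc3ccccc3[nH]2)nc1N1CCN(S(=O)(=O)c2ccccc2[N+](=O)[O-])CC1` keeps the shared core and the sulfonyl group but changes the ring carried on the sulfur: 2-nitrophenyl in place of 4-methylphenyl on a sulfonyl sulfur. In words, this is 2-nitrophenyl in place of 4-methylphenyl on a sulfonyl sulfur.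

Going by the values given here, only one measured step bears on this change, and only indirectly: a 1.1-fold higher number from compound 1 to compound 2 (0.05 log units; within the scatter). There, (4-methylphenyl)sulfonyl replaced methyl on an amine nitrogen in a ring, and the number stayed within the scatter. Among the compounds with values here, no measured pair varies the group on the sulfonyl sulfur, and no measured compound carries 2-nitrophenyl, so the range has to stay wide. No change beyond the scatter is expected in this assay, and no direction can be supported. The expected step is a 1.0-fold higher number from compound 2 to compound 3 (0.01 log units; within the scatter). For compound 3 the estimated value is 8 nM. The expected range for compound 3 runs from 3 nM to 22 nM.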

Compound 3, half-maximal inhibitory concentration: 3 nM
For compound 3 the middle estimate is 2.7-fold (0.43 log units) above the measured one; the measured number falls inside the stated range.
By their numbers in this assay, from the lowest: compound 3; then compounds 1 and 2 (each within the scatter of the next).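

In this assay the group on the sulfonyl sulfur is not neutral: 2-nitrophenyl in place of 4-methylphenyl gives a 2.6-fold lower number from compound 2 to compound 3 (0.42 log units; beyond the scatter), a modest step but one beyond the scatter. Measured against methyl on the amine nitrogen in a ring, (2-nitrophenyl)sulfonyl gives a 2.3-fold lower number from compound 1 to compound 3 (0.36 log units; beyond the scatter), whereas (4-methylphenyl)sulfonyl at the same place stayed within the scatter of methyl, so this position responds to some sulfonyl groups and not to others within the three compounds. No measured information available here accounts for the lower number of compound 3.

From the compounds shown here alone, with a single pair varying the ring on the sulfonyl sulfur, the nitro group cannot be separated from its place on that ring, and it remains open whether phenyl, 4-nitrophenyl or 2-methylphenyl on the same sulfur would read with compound 3 or with compound 2. Also open, going by these compounds, is whether a 2-aminophenyl ring or a plain ethyl on the sulfonyl sulfur would hold the step, and whether it carries over to any cell line other than this one.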